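Three Boron-Bearing Ketones and a Phenol Analogue

A few compounds are considered here, and "the series" means these few. Any claim that something is new, unique, unknown or untested is made for them only; others in the source may bear on it.

Compound 3 `COc1ccccc1C(=O)c1ccn(-c2ccc3c(c2)B(O)OC3)c1` is one of three closely related ketones tested in an ADME assay on L929 cells (Mus musculus) for cytotoxicity, read by resazurin assay, with a stated time of 72 h; on this read-out higher numbers stand for weaker inhibition and lower numbers for stronger inhibition. In this assay compound 3 gives > 10 ug/mL, which is a limit of the assay rather than a measured number. Compound 1 `O=C(c1ccn(-c2ccc3c(c2)B(O)OC3)c1)c1ccc(Cl)cc1Cl` likewise gives > 10 ug/mL, again a limit. Compound 2 `Cc1ccccc1C(=O)c1ccn(-c2ccc3c(c2)B(O)OC3)c1` gives > 10 ug/mL, also a limit. Because all three sit at the limit of > 10 ug/mL in this assay, at which 3 of the 3 values shown sit, the steps between them cannot be sized: the step that the two limits leave unreadable from compound 1 to compound 2, the step that the two limits leave unreadable from compound 1 to compound 3 and the step that the two limits leave unreadable from compound 2 to compound 3 are all unreadable, so the change of the aryl group on the carbonyl carbon has so far shown no measurable effect on cytotoxicity.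

Compound 4 `O=C(c1ccc(O)cc1)c1ccn(-c2ccc3c(c2)B(O)OC3)c1` has not yet been measured. It differs from compound 3 by 4-hydroxyphenyl in place of 2-methoxyphenyl on a carbonyl carbon. Every step bearing on this position was left unreadable by the limits, so there is no measured basis for expecting any step beyond the scatter in this assay, in either direction. The expectation is therefore that compound 4 will again reach the limit, with an estimated value of 30 ug/mL within 10 ug/mL to 100 ug/mL. This expectation amounts to an estimated step that the limit leaves unreadable from compound 3 to compound 4.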

Compound 4, half-maximal inhibitory concentration: > 10 ug/mL
Compound 4 gave a limit, no number; the forecaster's own chance of this, stated with the estimate: 85%; the middle value is on the limit's open side.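

Among these compounds, compound 4 also gives a limit rather than a number, so no step from compound 1, compound 2 or compound 3 to compound 4 can be read, because all four compounds stop at the same point: the limit of > 10 ug/mL in this assay, at which 4 of the 4 values shown sit. How strongly any of these compounds acts in this assay, and whether the aryl group on the carbonyl carbon matters there, remains open.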